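Adding a Methoxy Group to a Pyrazole Chalcone Scaffold

The compounds below may be only part of what the source reports. "The series", "measured", "known", "first", "only" and "open" are said of these compounds alone.

Measured so far:
compound 1 `O=C(/C=C\Nc1ccc(F)cc1)c1cn(-c2ccccc2)nc1-c1ccccc1` — 4670 nM
compound 2 `COc1ccc(N/C=C\C(=O)c2cn(-c3ccccc3)nc2-c2ccccc2)cc1` — 3250 nM

Both numbers come from a functional assay on A549 cells (Homo sapiens) for antiproliferative activity, read by MTT assay, with a stated time of 48 h; on this read-out lower numbers stand for stronger inhibition and higher numbers for weaker inhibition. Compound 1 gives the highest of the two numbers, and its nearest neighbour is compound 2, which sits within the scatter of it: a 1.4-fold lower number from compound 1 to compound 2 (0.16 log units; within the scatter). In that step a methoxy took the place of the fluoro on an aromatic carbon.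

Compound 3 `COc1ccc(-c2nn(-c3ccccc3)cc2C(=O)/C=C\Nc2ccc(F)cc2)cc1` keeps the fluoro of compound 1 and instead carries methoxy in place of hydrogen on an aromatic carbon. Within the data shown here, the only measured step that bears on this change is the one from compound 1 to compound 2, which introduced the same methoxy group at another aromatic carbon and stayed within the scatter. On that basis no step beyond the scatter is expected in this assay for compound 3, in either direction.

The expected value for compound 3 is 4000 nM, with a range from 1800 nM to 9000 nM, which corresponds to an estimated step of a 1.2-fold lower number from compound 1 to compound 3 (0.07 log units; within the scatter).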

Compound 3, half-maximal inhibitory concentration: 3980 nM
The estimate for compound 3 lay 1.0-fold (0.00 log units) above the measured number, and the stated range covers the measured number.
By their numbers in this assay, from the lowest: compounds 2, 3 and 1 (each within the scatter of the next).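

In this assay, going from phenyl to 4-methoxyphenyl gives a 1.2-fold lower number from compound 1 to compound 3 (0.07 log units; within the scatter), so a methoxy can stand on this aromatic carbon, para to a large group, without a step beyond the scatter. The earlier step only exchanged fluoro for methoxy at another aromatic carbon, whereas here the methoxy adds two heavy atoms where only a hydrogen stood, showing that this second place on the shared core also accepts the group in this cell assay. No measurement shown here explains why the number holds steady.

A single substituent at this carbon cannot show how far that acceptance extends. On these data alone, whether an amine, a carboxylic acid or a longer chain such as butoxy in place of the methoxy would give a step beyond the scatter remains open.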